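The source may hold more compounds than are shown below. What is called first, only, known or untested is meant among the compounds shown, and "the series" means these compounds.

Measured so far in an assay on HeLa cells for displacement of a labelled ligand from 5-hydroxytryptamine receptor 6 (Homo sapiens); a higher number here means a weaker inhibitor, a lower number a stronger inhibitor:
- compound 1, `CN1CCN(c2ccc3c(c2)c(S(=O)(=O)c2cccc4ccccc24)nn3Cc2ccccc2)CC1`: 2 nM
- compound 2, `CN1CCN(c2ccc3[nH]nc(S(=O)(=O)c4c(Cl)cccc4Cl)c3c2)CC1`: 2.6 nM

Compound 2 and compound 1 lie within the scatter of each other in this assay; the two numbers show no separation. Compound 3, `CN1CCN(c2ccc3[nH]nc(S(=O)(=O)c4cccs4)c3c2)CC1`, carries the change (thiophen-2-yl in place of 2,6-dichlorophenyl on a sulfonyl sulfur). Among the compounds with values here, no measured pair shows the effect of this change, so the size of the step is unknown from the data. A small loss is expected, because the value of compound 2 in this assay, 2.6 nM, leaves room for some weakening while the series stays potent. Compound 3 is estimated at 6 nM, with a range of 1.5 nM to 25 nM. The expected step is a 2.3-fold higher number from compound 2 to compound 3 (0.36 log units; beyond the scatter).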

Compound 3, inhibition constant: 7.8 nM
Compound 3: middle estimate off by 1.3-fold (0.11 log units), on the low side; low and high end bracket the measured number.
By their numbers in this assay, from the lowest: compounds 1 and 2 (each within the scatter of the next); then compound 3.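

In this assay, within the data shown here, thiophen-2-yl in place of 2,6-dichlorophenyl on a sulfonyl sulfur gives a 3.0-fold higher number from compound 2 to compound 3 (0.48 log units; beyond the scatter) as the first measured step at this position. Compound 3 at 7.8 nM still binds with a five-membered aromatic ring carrying a hetero atom, so this position is not limited to 2,6-dichlorophenyl. Nothing at hand accounts for the size of this step and its cause stays unassigned.

On these data alone, whether the loss follows from losing the chlorines or from changing the ring stays open; plain phenyl would separate the two. As far as these compounds go, how an amine or a carboxylic acid on this ring would read also remains open.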